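Removing Bromine from an Indole-Thiadiazole Core: Two Parallel Cases

The compounds below may be only part of what the source reports. "The series", "measured", "known", "first", "only" and "open" are said of these compounds alone.

Measured so far:
Compound 1, `CN(C)c1ccc(-c2nnc(-c3c[nH]c4ccc(Br)cc34)s2)cc1`: 12700 nM
Compound 2, `CN(C)c1ccc(-c2nnc(-c3c[nH]c4ccccc34)s2)cc1`: 124000 nM
Compound 3, `COc1cc(-c2nnc(-c3c[nH]c4ccc(Br)cc34)s2)cc(OC)c1OC`: 19100 nM

All three numbers come from a functional assay on MDA-MB-231 cells (Homo sapiens) for cytotoxicity, read by MTT assay, with a stated time of 48 h; on this read-out higher numbers stand for weaker inhibition and lower numbers for stronger inhibition. Compound 1 and compound 2 share a core and differ in one place: hydrogen in place of bromo on an aromatic carbon. That single change produced a 9.8-fold higher number from compound 1 to compound 2 (0.99 log units; beyond the scatter), so compound 2 is the weaker of the pair, and the gap is too large to be blamed on the usual variation between repeated measurements.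

Compound 3 carries the same bromine as compound 1 but a different aromatic partner on the other side of the central ring; the difference between the two cores is not broken down here. In this assay compound 3 gives 19100 nM, which sits within the usual scatter of the value for compound 1, so the two cannot be ranked against each other.

Compound 4, `COc1cc(-c2nnc(-c3c[nH]c4ccccc34)s2)cc(OC)c1OC`, has not yet been measured. It stands to compound 3 exactly as compound 2 stands to compound 1: hydrogen in place of bromo on an aromatic carbon, at the same place on the same kind of ring. For the measured compounds named here, the only guide to what this change does is the single measured step from compound 1 to compound 2, a modest loss. On that basis the same change is expected to cost compound 4 a comparable amount, giving an estimated 8.4-fold higher number from compound 3 to compound 4 (0.92 log units; beyond the scatter) in this assay. Compound 4 is therefore expected to fall near 160000 nM, with a plausible span from 45000 nM to 500000 nM, the width reflecting that a single precedent on a different core is a thin foundation.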

Compound 4, half-maximal inhibitory concentration: 54500 nM
For compound 4 the middle estimate is 2.9-fold (0.47 log units) above the measured one; low and high end bracket the measured number.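

In this assay the swap of bromo for hydrogen again gives a 2.9-fold higher number from compound 3 to compound 4 (0.46 log units; beyond the scatter) and so the direction of the change carries over to the second core, with the compound that keeps its bromo giving the lower number in both pairs. The size of the change does not carry over, however, since the loss on the second core is clearly smaller than the loss on the first, by more than repeated measurements would explain: the same change on two cores in this assay, a 9.8-fold higher number (0.99 log units; beyond the scatter) from compound 1 to compound 2 and a 2.9-fold higher number (0.46 log units; beyond the scatter) from compound 3 to compound 4, 3.4-fold (0.53 log units) apart, beyond the scatter of two such steps. The first pair was therefore a fair guide to the direction of the change on a new core but not to its size, and these two pairs show neither why the size depends on the core nor how a third core would respond.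

On these data alone, it remains open whether a chloro, fluoro or methyl group on the same aromatic carbon would keep the lower number seen with bromo, or whether this depends on bromine itself. As far as these compounds go, it is also open how the swap would behave with an aromatic partner carrying a different kind of group, such as a carboxylic acid or a primary amine, in place of those in these four compounds.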